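A Methoxymethyl Group Added at the Far Ring of Compound 2

This account rests on a few compounds, and the source may have more. Where it says the series, first, only, none or still open, it means among the compounds named here.

Going by the values given here, compound 2 `CC[C@H](C)[C@H](N)CN(C(=O)[C@@H]1C[C@H]1c1ccccn1)c1ccc(-c2ccccc2)cc1` gives 130 nM in a functional assay for agonist activity at G protein-coupled receptor 88 (Homo sapiens), read by HTRF and cAMP accumulation (on this read-out higher numbers stand for an effect only at larger amounts of compound and lower numbers for an effect already at smaller amounts), the lowest of the two numbers known; compound 1 `CC[C@H](C)[C@H](N)CN(C(=O)[C@@H]1C[C@H]1c1cccc(C#N)c1)c1ccc(-c2ccccc2)cc1` gives 1600 nM, and a 12-fold lower number from compound 1 to compound 2 (1.09 log units; beyond the scatter). Compound 3 `CC[C@H](C)[C@H](N)CN(C(=O)[C@@H]1C[C@H]1c1ccccn1)c1ccc(-c2ccc(COC)cc2)cc1` differs from compound 2 by methoxymethyl in place of hydrogen on an aromatic carbon, on an aromatic carbon of a six-membered aromatic ring of carbon only, para to a large group. Among the compounds with values here, the measured step concerns a different place, so no step bears on this change. No shift beyond the scatter is therefore expected, and compound 3 is estimated at 130 nM, range 40 nM to 450 nM, a step of no change at the digits printed from compound 2 to compound 3 (within the scatter).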

Compound 3, half-maximal effective concentration: 15 nM
For compound 3 the middle estimate is 8.7-fold (0.94 log units) above the measured one; measured number below the stated range.
By their numbers in this assay, from the lowest: compound 3; then compound 2; then compound 1.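

In this assay, methoxymethyl in place of hydrogen on an aromatic carbon of the far ring, para to a large group, gives an 8.7-fold lower number from compound 2 to compound 3 (0.94 log units; beyond the scatter). This is the first change shown at this ring, and it shows that the position accepts a substituent and that the number moves with it; the earlier step concerned a different place. Nothing shown gives a reason for this step.

As far as these compounds go, whether the oxygen is needed stays open, as an ethyl chain or a hydroxymethyl group at this position would show. Also open, from the compounds shown here alone, is whether methoxymethyl would lower the number equally on compound 1.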